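Swapping Fluoro for Trifluoromethyl on the Aryl Ring

The source may report more compounds than this note shows. Statements on the series, on what has been measured and on what is new or still open speak of the compounds shown alone.

Measured compounds:
compound 1 `O=C(O)Cc1sc(C(c2ccccc2)c2ccccc2)nc1-c1ccc(F)cc1`: 80%
compound 2 `O=C(O)Cc1sc(C(c2ccccc2)c2ccc(F)c(F)c2)nc1-c1ccc(F)cc1`: 80%

In an in vitro functional assay on HEK285-7 cells for antagonist activity at prostaglandin D2 receptor 2 (Homo sapiens), read by BRET and beta-arrestin recruitment (a higher number here means a larger maximal response, a lower number a smaller maximal response), compound 1 gives 80% and compound 2 gives 80%, the two level within the scatter. Within the data shown here, the only measured step, no change at the digits printed from compound 1 to compound 2 (within the scatter), concerned a different part of the molecule. Compound 3 `O=C(O)Cc1sc(C(c2ccccc2)c2ccccc2)nc1-c1ccc(C(F)(F)F)cc1` differs from compound 1 by trifluoromethyl in place of fluoro on an aromatic carbon. Among the measured compounds shown here, no measured step bears on this change, so nothing beyond the scatter is expected: the step of no change at the digits printed from compound 1 to compound 3 (within the scatter) is estimated. Compound 3 is therefore expected to give 80%, between 65% and 92%.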

Compound 3, largest response reached (reported as efficacy), in percent of the reference or control that the assay uses: 80%
Compound 3: middle estimate and measured number agree at the digits printed; the measured number falls inside the stated range.
By their numbers in this assay, from the lowest: compounds 1, 2 and 3 (each within the scatter of the next).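

In this assay there is no change at the digits printed from compound 1 to compound 3 (within the scatter), so at this ring carbon the maximal response tolerates trifluoromethyl, with its four heavy atoms, in place of the single fluoro atom. Among these compounds, the earlier pair concerned a different part of the molecule, which makes this the first reading at this position. No available evidence accounts for the unchanged response. Going by these compounds, whether an amine or a methoxy group on this carbon would leave the response equally unchanged remains open, and so does the outcome of combining trifluoromethyl here with the 3,4-difluorophenyl group of compound 2.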